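Dimethylamino in place of cyclobutylmethylamino on a shared core

The source may hold more compounds than are shown below. What is called first, only, known or untested is meant among the compounds shown, and "the series" means these compounds.

Compound 1 `CNc1nc(C)c(-c2nc3ccccc3s2)c(N[C@@H]2C[C@H](CO)[C@@H](O)[C@H]2O)n1` and compound 2 `Cc1nc(NCC2CCC2)nc(N[C@@H]2C[C@H](CO)[C@@H](O)[C@H]2O)c1-c1nc2ccccc2s1` share one core and were both examined in an ADME assay on cells (Homo sapiens) for cytotoxicity, read by polymerase chain reaction, with a stated time of 3 days; on this read-out higher numbers stand for lower toxicity in this test and lower numbers for higher toxicity in this test. In this assay compound 1 reaches only a limit of the assay, > 25000 nM, and not a number. In this assay compound 2 likewise stops at a limit, > 25000 nM. Among the compounds with values here, compound 2 thus stands at a limit beside the one other value shown, as the limit of > 25000 nM in this assay, at which 2 of the 2 values shown sit, records. Compound 3 `Cc1nc(N(C)C)nc(N[C@@H]2C[C@H](CO)[C@@H](O)[C@H]2O)c1-c1nc2ccccc2s1` is the next member, with one change: dimethylamino in place of (cyclobutylmethyl)amino on an aromatic carbon. Within the data shown here, the only measured step that bears on this change is a step that the two limits leave unreadable from compound 1 to compound 2, which offers no readable size and so no direction. The estimated step that the limit leaves unreadable from compound 2 to compound 3 is therefore expected to be none beyond the scatter, with the result most likely again a limit. The estimated value for compound 3 in this assay is 30000 nM, within a range from 12000 nM to 80000 nM.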

Compound 3, half-maximal cytotoxic concentration: 18000 nM
Compound 3: middle estimate off by 1.7-fold (0.22 log units), on the high side; low and high end bracket the measured number.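

Compound 3 is the only one of the three that gives a number in this assay, so at this aromatic carbon, between two ring nitrogen atoms, dimethylamino brings the read-out within the range the assay can report. Dimethylamino in place of (cyclobutylmethyl)amino gives an at least 1.3-fold lower number from compound 2 to compound 3 (0.14 log units; that floor lies within the scatter) and methyl in place of hydrogen on the nitrogen gives an at least 1.3-fold lower number from compound 1 to compound 3 (0.14 log units; that floor lies within the scatter) and both are floors only, so neither shows a change beyond the usual scatter. Compound 1 and compound 2 each stop at a limit of the assay, so the step joining them cannot be read: the limit of > 25000 nM in this assay, at which 2 of the 3 values shown sit.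

The compounds shown leave open how far compound 1 and compound 2 truly lie from compound 3. They also leave open how a carboxylic acid or an amine with a longer chain at this carbon would read in this assay.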